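The compounds below may be only part of what the source reports. "The series", "measured", "known", "first", "only" and "open" are said of these compounds alone.

Measured compounds, antiproliferative read-out:

Compound 1 `CC1=CC[C@H]2[C@H](CC[C@]2(C)O)C(C)(C)[C@@H]1CC[C@H]1[C@]2(C)CC[C@H](OC(=O)c3ccc(F)cc3)C(C)(C)O[C@H]2CC[C@@]1(C)O` gives 33500 nM in a functional assay on MCF7 cells (Homo sapiens) for antiproliferative activity, read by MTT assay, with a stated time of 72 h; a lower number here means a stronger inhibitor, a higher number a weaker inhibitor.
Compound 2 `CC1=CC[C@H]2[C@H](CC[C@]2(C)O)C(C)(C)[C@@H]1CC[C@H]1[C@]2(C)CC[C@H](OC(=O)c3ccc(C(F)(F)F)cc3)C(C)(C)O[C@H]2CC[C@@]1(C)O` gives 23400 nM in this assay.
Compound 3 `CC1=CC[C@H]2[C@H](CC[C@]2(C)O)C(C)(C)[C@@H]1CC[C@H]1[C@]2(C)CC[C@H](OC(=O)c3ccccc3F)C(C)(C)O[C@H]2CC[C@@]1(C)O` gives 11300 nM in this assay.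

The three measured esters share one core and differ only in the aromatic acid part. Compound 1 and compound 2 differ by trifluoromethyl in place of fluoro on an aromatic carbon, and this change produced a 1.4-fold lower number from compound 1 to compound 2 (0.16 log units; within the scatter). Compound 1 and compound 3 differ by 2-fluorophenyl in place of 4-fluorophenyl on a carbonyl carbon, with a 3.0-fold lower number from compound 1 to compound 3 (0.47 log units; beyond the scatter). Between compound 2 and compound 3 the step is a 2.1-fold lower number from compound 2 to compound 3 (0.32 log units; beyond the scatter). Compound 3 thus gives the lowest number of the three, with both of its steps to the others beyond the scatter.

Compound 4 `CC1=CC[C@H]2[C@H](CC[C@]2(C)O)C(C)(C)[C@@H]1CC[C@H]1[C@]2(C)CC[C@H](OC(=O)c3ccccc3C(F)(F)F)C(C)(C)O[C@H]2CC[C@@]1(C)O` has not yet been measured in this assay. It differs from compound 3 by trifluoromethyl in place of fluoro on an aromatic carbon. Among the compounds with values here, this is the same kind of change as the one from compound 1 to compound 2, but not the same: in compound 1 to compound 2 the exchanged group sits para to a large group, whereas in compound 3 to compound 4 it sits ortho to a large group.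

Within the data shown here, the only precedent for this kind of change is the step from compound 1 to compound 2, which stayed within the scatter. On that basis a step of similar size is expected from compound 3 to compound 4 in this assay, namely a 1.3-fold lower number from compound 3 to compound 4 (0.10 log units; within the scatter), with wide uncertainty since the surroundings of the exchanged group are not the same. Compound 4 is therefore estimated at 9000 nM in this assay, between 4000 nM and 20000 nM.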

Compound 4, half-maximal inhibitory concentration: 19200 nM
Estimate against measurement, compound 4: 2.1-fold (0.33 log units) below; low and high end bracket the measured number.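

In this assay, trifluoromethyl in place of fluoro on an aromatic carbon ortho to a large group gives a 1.7-fold higher number from compound 3 to compound 4 (0.23 log units; within the scatter), and the other two steps to compound 4 also stay within the scatter, at a 1.2-fold lower number from compound 2 to compound 4 (0.09 log units; within the scatter) and a 1.7-fold lower number from compound 1 to compound 4 (0.24 log units; within the scatter). Set beside the para case, the ortho case does not differ from it beyond what two such steps would scatter, so the change carries across this pair of esters as a small step in both settings: the same change on two cores in this assay, a 1.4-fold lower number (0.16 log units; within the scatter) from compound 1 to compound 2 and a 1.7-fold higher number (0.23 log units; within the scatter) from compound 3 to compound 4, 2.4-fold (0.39 log units) apart, within the scatter of two such steps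
The two steps point in opposite directions as printed, but neither they nor the gap between them lie beyond the scatter, so this shows no real effect of the change at either place and no effect of where it sits, and two pairs cannot show that the same would hold for other esters in the series.

Open, as far as these compounds go, is whether an amine, a carboxylic acid or a methoxy group on the same aromatic ring would give a step beyond the scatter in this assay, and whether such a step would hold at both places on the ring. Also open, from the compounds shown here alone, is whether an amide linkage in place of the ester would leave these small steps as they stand.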